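The source may hold more compounds than are shown below. What is called first, only, known or untested is meant among the compounds shown, and "the series" means these compounds.

Compound 1 `Nc1nc(O)c2c(n1)n(C1OC(CO)[C@@H](O)[C@H]1O)c(=O)n2C/C=C/c1ccccc1` gives 4 uM in a functional assay with Mus musculus as the target; a higher number here means that more compound is needed for the effect, a lower number that less compound is needed.
Compound 2 `Cn1c(=O)n(C2OC(CO)[C@@H](O)[C@H]2O)c2nc(N)nc(O)c21` gives 120 uM in this assay.

Among the compounds with values here, compound 2 stands at the higher end of these two numbers: its only neighbour is compound 1, and the change a 30-fold higher number from compound 1 to compound 2 (1.48 log units; beyond the scatter) shows how much more of compound 2 is needed than of compound 1. Compound 3 `NC(=O)Cn1c(=O)n(C2OC(CO)[C@@H](O)[C@H]2O)c2nc(N)nc(O)c21` is not yet measured. It differs from compound 2 by a single change: carbamoyl in place of hydrogen on a saturated chain carbon bound to an aromatic nitrogen. Within the data shown here, the one measured step that bears on it is the step from compound 1 to compound 2, which sits at the same place, where the loss of 2-phenylethenyl gave the large rise just noted. A carbamoyl is a much smaller and quite different group than 2-phenylethenyl, so a step of that size is not expected; a moderate fall in the number is expected instead, roughly a 2.0-fold lower number from compound 2 to compound 3 (0.30 log units; within the scatter). Compound 3 is therefore estimated at 60 uM, within 15 uM to 200 uM.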

Compound 3, concentration for half-maximal effect: 117 uM
Beside the measured number, compound 3's estimate is 2.0-fold (0.29 log units) below it; measured number inside the range.
By their numbers in this assay, from the lowest: compound 1; then compounds 3 and 2 (each within the scatter of the next).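

At this place, on a saturated chain carbon bound to an aromatic nitrogen, carbamoyl and hydrogen cannot be told apart in this assay, with a 1.0-fold lower number from compound 2 to compound 3 (0.01 log units; within the scatter) between them. Setting carbamoyl in place of 2-phenylethenyl gives a 29-fold higher number from compound 1 to compound 3 (1.47 log units; beyond the scatter), so of the three compounds, only the one carrying 2-phenylethenyl needs clearly less compound. Three heavy atoms with a hydrogen-bond donor and acceptor are thus not enough on their own to shift the number from that of the hydrogen compound. Nothing measured here explains these numbers.

Still open, from the compounds shown here alone, is whether the phenyl ring, the double bond or simply the chain length matters in 2-phenylethenyl; a benzyl group or a plain propyl chain at this place would help separate these. Going by these compounds, how an amine or a carboxylic acid would read here is also open.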